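Moving the Bromine: an Expected Value for Compound 3

The source may hold more compounds than are shown below. What is called first, only, known or untested is meant among the compounds shown, and "the series" means these compounds.

Compound 1, `Fc1cccc(-c2nc(Nc3ccccc3Cl)c3cc(F)ccc3n2)c1`: in a functional assay on MCF7 cells (Homo sapiens) for cytotoxicity, read by MTT assay, with a stated time of 48 h (on this read-out higher numbers stand for weaker inhibition and lower numbers for stronger inhibition), compound 1 reaches only the limit > 50000 nM.
Compound 2, `Fc1cccc(-c2nc(Nc3cccc(Br)c3)c3cc(F)ccc3n2)c1`: in this assay compound 2 reaches only the limit > 50000 nM.

Compound 2 stands at the limit of the assay rather than at a measured number. The same holds for compound 1, as the limit of > 50000 nM in this assay, at which 2 of the 2 values shown sit, shows. Within the data shown here, the one measured step, a step that the two limits leave unreadable from compound 1 to compound 2, therefore gives no readable size, and it tells nothing about whether the change in that step helps or hurts.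

Compound 3, `Fc1cccc(-c2nc(Nc3ccccc3Br)c3cc(F)ccc3n2)c1`, differs from compound 2 by 2-bromophenyl in place of 3-bromophenyl on a nitrogen on an aromatic ring. Among the measured compounds shown here, no measured step bears directly on this change. The only shown step also alters the group on that nitrogen, yet it cannot be read, so it offers no direction and no size.

Compound 3 is expected to stay at the limit, given that compound 2 itself gives only the limit > 50000 nM in this assay. The expected step that the limit leaves unreadable from compound 2 to compound 3 thus means no change beyond the scatter. The estimate for compound 3 is 70000 nM, ranging from 20000 nM to 250000 nM.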

Compound 3, half-maximal inhibitory concentration: > 50000 nM
Compound 3 ended at the assay's limit; the forecaster's own chance of this, stated with the estimate: 85%; the middle value lies beyond the limit too.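

No step among compound 1, compound 2 and compound 3 can be read, since each gives only a limit and not a measured number: the limit of > 50000 nM in this assay, at which 3 of the 3 values shown sit.

The compounds shown leave open whether 2-bromophenyl, 3-bromophenyl or the chloro counterpart differ at all in this assay, and which change to the shared core would give a readable value.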